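Cyano to Diethoxymethyl in a Cytotoxicity Series

The source may report more compounds than this note shows. Statements on the series, on what has been measured and on what is new or still open speak of the compounds shown alone.

Compound 1 `CC1=C(/C=C/C(=O)/C=C/c2cccc(C)c2)C(C)(C)CCC1O`: 4100 nM
Compound 2 `CC1=C(/C=C/C(=O)/C=C/c2cccc(C#N)c2)C(C)(C)CCC1O`: 1800 nM

Of the compounds shown here, two have so far been measured in a functional assay on LNCaP cells (Homo sapiens) for cytotoxicity, read by MTT assay, with a stated time of 72 h; on this read-out higher numbers stand for weaker inhibition and lower numbers for stronger inhibition. In this assay, among the compounds with values here, compound 1 gives 4100 nM and compound 2 gives 1800 nM; the one measured step is a 2.3-fold lower number from compound 1 to compound 2 (0.36 log units; beyond the scatter), a modest change. Within the data shown here, compound 2 therefore stands at the lowest of the two numbers, with compound 1 as its only neighbour.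

Compound 3 `CCOC(OCC)c1cccc(/C=C/C(=O)/C=C/C2=C(C)C(O)CCC2(C)C)c1` differs from compound 2 by diethoxymethyl in place of cyano on an aromatic carbon. Among the measured compounds shown here, no measured step tries a group of this kind; the only step available, a 2.3-fold lower number from compound 1 to compound 2 (0.36 log units; beyond the scatter), exchanged methyl for cyano and bears on the present change only loosely, since the entering group resembles neither. With so thin a basis, the expected step in this assay is small and within the scatter, a 1.6-fold higher number from compound 2 to compound 3 (0.19 log units; within the scatter). For compound 3 the estimate is 2800 nM, with a range from 900 nM to 9000 nM.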

Compound 3, half-maximal inhibitory concentration: 1800 nM
Compound 3: the middle estimate sits 1.6-fold (0.19 log units) above what was measured; low and high end bracket the measured number.
By their numbers in this assay, from the lowest: compounds 2 and 3 (each within the scatter of the next); then compound 1.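

Swapping cyano for diethoxymethyl on this aromatic carbon brings in a group of 7 heavy atoms in place of one of 2, yet this assay shows no change at the digits printed from compound 2 to compound 3 (within the scatter). Measured against methyl, the new group gives a 2.3-fold lower number from compound 1 to compound 3 (0.36 log units; beyond the scatter), so at this place a group with no triple bond matches what cyano achieved, and the lower number seen with cyano is not tied to the nitrile. Nothing measured on these compounds accounts for this outcome.

The three compounds shown leave open whether a carboxylic acid, an amine or an aldehyde at this place would stay at the level of compound 2 and compound 3 or depart from it. They also leave open whether a smaller acetal or a longer alkoxy chain would read the same.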